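This account rests on a few compounds, and the source may have more. Where it says the series, first, only, none or still open, it means among the compounds named here.

Compound 1 `C/C=C1/[C@H](O[C@@H]2O[C@H](CO)[C@@H](O)[C@H](O)[C@H]2O)OC=C(C(=O)OC)[C@H]1CC(=O)OCCc1ccc(OC)c(OC)c1` gives > 15000 nM in a functional assay on SK-BR-3 cells (Homo sapiens) for antiproliferative activity, read by MTT assay, with a stated time of 72 h (on this read-out lower numbers stand for stronger inhibition and higher numbers for weaker inhibition), which is a limit of the assay rather than a number.
Compound 2 `C/C=C1/[C@H](O[C@@H]2O[C@H](COC(C)=O)[C@@H](OC(C)=O)[C@H](OC(C)=O)[C@H]2OC(C)=O)OC=C(C(=O)OC)[C@H]1CC(=O)OCCC1CCCCC1` gives > 15000 nM in this assay, again only a limit.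
Compound 3 `C/C=C1/[C@H](O[C@@H]2O[C@H](COC(C)=O)[C@@H](OC(C)=O)[C@H](OC(C)=O)[C@H]2OC(C)=O)OC=C(C(=O)O)[C@H]1CC(=O)OCCCCCCCCCCCCCCC` gives > 20000 nM in this assay, also a limit.

Compound 1 therefore stands at a limit, with no measured number of its own. For the measured compounds named here, the other two measured compounds likewise sit at limits, two of the three values at the limit of > 15000 nM in this assay, at which 2 of the 3 values shown sit, and one at the limit of > 20000 nM in this assay, at which 1 of the 3 values shown sits, so none of the three shows measurable inhibition of growth in these cells and no step between measured compounds can be read off.

The unmeasured compound 4 `C/C=C1/[C@H](O[C@@H]2O[C@H](CO)[C@@H](O)[C@H](O)[C@H]2O)OC=C(C(=O)OC)[C@H]1CC(=O)OCCC(C)C` differs from compound 1 in one place: isopropyl in place of 3,4-dimethoxyphenyl on a saturated chain carbon, two bonds along the chain from an oxygen next to a carbonyl group. Going by the values given here, with every measured value sitting at a limit, there is no measured step to lean on. The step from compound 1 to compound 4 a step that the limit leaves unreadable from compound 1 to compound 4 is expected to be none beyond the scatter, with compound 4 most likely again reported only as a limit. Compound 4 is estimated at 20000 nM, with a range from 8000 nM to 50000 nM.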

Compound 4, half-maximal inhibitory concentration: 9020 nM
For compound 4 the middle estimate is 2.2-fold (0.35 log units) above the measured one, and the stated range covers the measured number.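

For the compounds shown here, compound 4 is the first compound here with a measured number rather than a limit: in this assay it gives 9020 nM with isopropyl at this place, on a saturated chain carbon, two bonds along the chain from an oxygen next to a carbonyl group. The change gives an at least 1.6-fold lower number from compound 1 to compound 4 (0.22 log units; that floor lies within the scatter) and shows that a measured number at this place does not require the 3,4-dimethoxyphenyl group. The true size of the step cannot be read, because compound 1 has only a limit: the limit of > 15000 nM in this assay, at which 2 of the 4 values shown sit.

The compounds shown leave open whether a plain phenyl ring, an amine or a carboxylic acid in this place would give a lower or a higher number than isopropyl. Steps to compound 2 and compound 3 cannot be read, since those compounds differ from the others in more than one place and have only limits.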